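This account rests on a few compounds, and the source may have more. Where it says the series, first, only, none or still open, it means among the compounds named here.

Measured in a functional assay on MDA-MB-231 cells (Homo sapiens) for antiproliferative activity, read by MTT assay; on this read-out lower numbers stand for stronger inhibition and higher numbers for weaker inhibition:
compound 1, `CC/C=C\C/C=C\C/C=C\CCCCCCCc1cc(=O)c2c(O)c(C)c(O)c(C)c2o1`: 6790 nM
compound 2, `CC/C=C\C/C=C\C/C=C\CCCCCCCc1cc(=O)c2c(O)c(C)c(OCOC)c(C)c2o1`: 16100 nM
compound 3, `CCCCC/C=C\C/C=C\CCCCCCCc1cc(=O)c2c(O)c(C)c(OCOC)cc2o1`: > 87000 nM, a limit of the assay

Compound 1 and compound 2 share one core; the change between them, (hydrogen in place of methoxymethyl on an oxygen on an aromatic ring), gives a 2.4-fold lower number from compound 2 to compound 1 (0.37 log units; beyond the scatter). Compound 3 sits at the limit of > 87000 nM in this assay, at which 1 of the 3 values shown sits. How the core of compound 3 differs from that of compound 2 is not broken down here. Compound 4, `CCCCC/C=C\C/C=C\CCCCCCCc1cc(=O)c2c(O)c(C)c(O)cc2o1`, is not yet measured; it arises from compound 3 by the same change, (hydrogen in place of methoxymethyl on an oxygen on an aromatic ring), at the same place. From compound 3 to compound 4 a step of similar size is expected, an at least 2.1-fold lower number from compound 3 to compound 4 (0.33 log units; beyond the scatter), resting on a 2.4-fold lower number from compound 2 to compound 1 (0.37 log units; beyond the scatter). The value of compound 3 is a limit, and the starting point is thus not fixed; a limit for compound 4 remains possible. Compound 4 is expected at 40000 nM, between 15000 nM and 120000 nM.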

Compound 4, half-maximal inhibitory concentration: 16100 nM
Compound 4: the middle estimate sits 2.5-fold (0.40 log units) above what was measured; low and high end bracket the measured number.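

In this assay, hydroxy in place of methoxymethoxy also gives a lower number on the second core, with an at least 5.4-fold lower number from compound 3 to compound 4 (0.73 log units; beyond the scatter), so the direction of the change carries over between the two cores shown. For compound 3, > 87000 nM is a limit of the assay, so the size of this step is not fixed. The data therefore show a shared direction but not a shared size: the same change on two cores in this assay, a 2.4-fold lower number (0.37 log units; beyond the scatter) from compound 2 to compound 1 and an at least 5.4-fold lower number (0.73 log units; beyond the scatter) from compound 3 to compound 4; the limit leaves it open whether they differ

Two cores are too few to show how far this direction extends across the series. As far as these compounds go, what a methyl ether or an acetyl ester on the same oxygen would give stays open, as does the effect of a longer chain on either core.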